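This account rests on a few compounds, and the source may have more. Where it says the series, first, only, none or still open, it means among the compounds named here.

Measured in a functional assay on CAKI-1 cells (Homo sapiens) for cytotoxicity, read by sulforhodamine B assay, with a stated time of 48 h; a lower number here means that less compound is tolerated, a higher number that more compound is tolerated:
compound 1 `ClCc1ccc(Cn2cnc3c(Cl)ncnc32)cc1` gives 2390 nM
compound 2 `ClCc1ccccc1Cn1cnc2ncnc(Cl)c21` gives 7410 nM

Within the data shown here, of these two, compound 2 has the highest number; the only other compound, compound 1, lies beyond the scatter below it. Compound 3 `ClCc1ccccc1Cn1cnc2nc(Cl)nc(Cl)c21` differs from compound 2 in one place: chloro in place of hydrogen on an aromatic carbon. Among the measured compounds shown here, no pair of measured compounds shows this kind of change, so nothing here tells how it acts. In this assay no step beyond the scatter is expected for compound 3. Compound 3 is therefore estimated at 5500 nM, within 1800 nM to 16000 nM. This estimate means an expected step of a 1.3-fold lower number from compound 2 to compound 3 (0.13 log units; within the scatter), inside the scatter.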

Compound 3, concentration lethal to 50% of the cells: 61700 nM
Estimate against measurement, compound 3: 11-fold (1.05 log units) below, and the stated range ends below it.
By their numbers in this assay, from the lowest: compound 1; then compound 2; then compound 3.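

In this assay, chloro in place of hydrogen on the aromatic carbon between two ring nitrogen atoms brings an 8.3-fold higher number from compound 2 to compound 3 (0.92 log units; beyond the scatter), so more compound is tolerated. This position is therefore not silent: a single added chlorine atom there moves the read-out beyond the usual scatter. Nothing shown explains this step. Going by these compounds, whether an amine or a methoxy group on the same carbon would shift the number in the same direction stays open. So does whether chloro here would act alike on the core of compound 1.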